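Shortening the Amide Substituent on the Shared Core

The source may hold more compounds than are shown below. What is called first, only, known or untested is meant among the compounds shown, and "the series" means these compounds.

Within the data shown here, compound 1 `CC(C)N1CC[C@H](NC(=O)c2cc(-c3ccc(NS(=O)(=O)c4cccc(Cl)c4Cl)cc3)nc3[nH]ncc23)C1` is the only compound with a number in an assay for inhibition of serine/threonine-protein kinase Sgk1 (Homo sapiens), with stated times of 30 min and 60 min, in the presence of a further agent that is not named here; on this read-out higher numbers stand for weaker inhibition and lower numbers for stronger inhibition: compound 1 gives 38 nM. Compound 2 `CCNC(=O)c1cc(-c2ccc(NS(=O)(=O)c3cccc(Cl)c3Cl)cc2)nc2[nH]ncc12` differs from it by ethyl in place of 1-isopropylpyrrolidin-3-yl on an amide-type nitrogen. In this assay compound 2 is reported only as a limit, < 1920 nM. The step that the limit leaves unreadable from compound 1 to compound 2 cannot be sized because of the limit of < 1920 nM in this assay, at which 1 of the 2 values shown sits. Compound 3 `NCCNC(=O)c1cc(-c2ccc(NS(=O)(=O)c3cccc(Cl)c3Cl)cc2)nc2[nH]ncc12` carries the change (2-aminoethyl in place of 1-isopropylpyrrolidin-3-yl on an amide-type nitrogen). Among the measured compounds shown here, the one measured step that bears on this change, from compound 1 to compound 2, has no readable size, so the measured data give neither a direction nor a magnitude for the change to compound 3. Compound 3 is therefore expected to sit in the neighbourhood of compound 1, with a wide range around that expectation. In this assay compound 3 is estimated at 110 nM, between 25 nM and 600 nM, which corresponds to an expected step of a 2.9-fold higher number from compound 1 to compound 3 (0.46 log units; beyond the scatter).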

Compound 3, half-maximal inhibitory concentration: < 1 nM
Compound 3: only a limit was reported; the forecaster's own chance of this, stated with the estimate: 20%; middle value at least 110-fold (2.04 log units) away from the limit.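

At this amide-type nitrogen, the 1-isopropylpyrrolidin-3-yl group is not required for strong inhibition in this assay, as replacing it with 2-aminoethyl gives an at least 38-fold lower number from compound 1 to compound 3 (1.57 log units; beyond the scatter). Compound 3 is reported only as a limit, < 1 nM. The steps involving the other limit cannot be read, so the amino group that separates compound 3 from compound 2 has no measured contribution here.

Because the whole group changes at once from compound 1 to compound 3, the compounds shown do not separate the loss of the ring from the gain of the primary amine. As far as these compounds go, it also remains open how a longer chain such as 3-aminopropyl, or a 2-hydroxyethyl group in place of 2-aminoethyl, would behave at this nitrogen.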